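The source may hold more compounds than are shown below. What is called first, only, known or untested is meant among the compounds shown, and "the series" means these compounds.

Measured compounds in a functional assay on the whole organism for inhibition, with Rattus norvegicus as the target, read by paw edema, with stated times of 1 h and 0.5 h, at a dose of 100 mg/kg by the oral route; on this read-out higher numbers stand for more inhibition at the one dose given (going by the name of the read-out) and lower numbers for less inhibition:
Compound 1, `O=C(O)c1ccc(NC(=O)[C@@H]2CC(O)CN2S(=O)(=O)c2ccc([N+](=O)[O-])cc2)cc1`, gives 44.1%.
Compound 2, `Cc1ccc(S(=O)(=O)N2CC(O)C[C@H]2C(=O)Nc2ccc(C(=O)O)cc2)cc1`, gives 58%.
Compound 3, `Cc1ccc(S(=O)(=O)N2CCC[C@H]2C(=O)Nc2ccc(C(=O)O)cc2)cc1`, gives 28.8%.

Compound 3 stands lowest of the three, with compound 1 nearest and compound 2 furthest, both beyond the scatter. Two single changes connect the measured compounds. From compound 2 to compound 1 the change is nitro in place of methyl on an aromatic carbon, and the step is a number 13.9 percentage points lower from compound 2 to compound 1 (beyond the scatter). From compound 2 to compound 3 the change is hydrogen in place of hydroxy on a saturated ring carbon, and the step is a number 29.2 percentage points lower from compound 2 to compound 3 (beyond the scatter); this is also how the core of compound 3 differs from the core of compound 2.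

Compound 4, `O=C(O)c1ccc(NC(=O)[C@@H]2CCCN2S(=O)(=O)c2ccc([N+](=O)[O-])cc2)cc1`, has not yet been measured. Among the compounds with values here, it differs from compound 3 by nitro in place of methyl on an aromatic carbon, the same change as the one from compound 2 to compound 1, made here on the core that carries hydrogen instead of hydroxy. Within the data shown here, since the only example of this change gave the step of a number 13.9 percentage points lower from compound 2 to compound 1 (beyond the scatter), a drop of similar size is expected from compound 3, namely a number 13.8 percentage points lower from compound 3 to compound 4 (beyond the scatter). With that single precedent, and a wide allowance for scatter at a low starting value, compound 4 is estimated at 15%, between 0% and 32%.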

Compound 4, a percentage reported as inhibition, in the whole organism at one dose (the size of the read-out at that dose, not a potency): 42.1%
Compound 4: middle estimate off by 27.1 percentage points, on the low side; measured number above the stated range.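

In this assay, nitro in place of methyl on an aromatic carbon gave a number 13.3 percentage points higher from compound 3 to compound 4 (beyond the scatter), so the change did not carry over in direction or size from the core of compound 2 to the core of compound 3: the same change on two cores in this assay, a number 13.9 percentage points lower (beyond the scatter) from compound 2 to compound 1 and a number 13.3 percentage points higher (beyond the scatter) from compound 3 to compound 4, 27.2 percentage points apart, beyond the scatter of two such steps

Hydrogen in place of hydroxy on a saturated ring carbon likewise depended on the other group present, giving a number 2 percentage points lower from compound 1 to compound 4 (within the scatter), unlike the step seen with methyl: the same change on two cores in this assay, a number 29.2 percentage points lower (beyond the scatter) from compound 2 to compound 3 and a number 2 percentage points lower (within the scatter) from compound 1 to compound 4, 27.2 percentage points apart, beyond the scatter of two such steps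

Within these four compounds, then, the two changes do not act independently, and a step measured on one core cannot simply be transferred to the other, though the data do not show why this is so or whether it would hold for any other pair of groups.

The compounds shown leave open how a chlorine, a methoxy group or an amine on that aromatic carbon would behave on either core. They also leave open what a methyl ester or a primary amide in place of the carboxylic acid would do to either step.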